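A few compounds are considered here, and "the series" means these few. Any claim that something is new, unique, unknown or untested is made for them only; others in the source may bear on it.

Of the compounds shown here, three have been measured in an assay on Sf9 cells for inhibition of histone deacetylase 11 (Homo sapiens), read by fluorescence, tested at 0.5 uM; on this read-out higher numbers stand for more inhibition at the one concentration tested (going by the name of the read-out) and lower numbers for less inhibition. Compound 1 `O=C(NO)c1ccc(-c2cn([C@@H]3C[C@H](CO)N(Cc4ccccc4)C3)nn2)cc1` carries a hydroxymethyl group on a saturated ring carbon, and in this assay compound 1 gives 14%. Compound 2 `O=C(NO)c1ccc(-c2cn([C@@H]3C[C@H](C(=O)O)N(Cc4ccccc4)C3)nn2)cc1` carries a carboxy group at that same place. For compound 2 this assay reports only a limit, < 10%. The step of a number at least 4 percentage points higher from compound 2 to compound 1 (that floor lies within the scatter) is the change (hydroxymethyl in place of carboxy on a saturated ring carbon). Compound 3 `O=C(NO)c1cccc(-c2cn([C@H]3C[C@H](C(=O)O)N(Cc4ccccc4)C3)nn2)c1` is built from the same atoms as compound 2, joined differently; how the two cores differ is not broken down here. For compound 3 this assay likewise reports only a limit, < 10%. That two of the three values sit at one point is captured by the limit of < 10% in this assay, at which 2 of the 3 values shown sit.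

Compound 4 `O=C(NO)c1cccc(-c2cn([C@H]3C[C@H](CO)N(Cc4ccccc4)C3)nn2)c1` has not yet been measured. It stands to compound 3 as compound 1 stands to compound 2, through the same change, (hydroxymethyl in place of carboxy on a saturated ring carbon), at a place described in identical words. Because the measured step of a number at least 4 percentage points higher from compound 2 to compound 1 (that floor lies within the scatter) lies within the scatter, the step of a number at least 2 percentage points higher from compound 3 to compound 4 (that floor lies within the scatter) is expected to be of similar, modest size. Compound 4 is therefore estimated at 12%, with a likely span from 0% to 25%.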

Compound 4, a percentage reported as inhibition, at one concentration (the size of the read-out at that concentration, not a potency): < 10%
Compound 4: a limit, no number (the forecaster's own chance of this, stated with the estimate: 40%); at least 2 percentage points between middle value and limit.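

Compound 3 and compound 4 both end at a limit of the assay, not at a number, so no step can be read between them: the limit of < 10% in this assay, at which 3 of the 4 values shown sit.

The compounds shown leave open how far compound 2, compound 3 and compound 4 lie under that limit, and whether hydroxymethyl in place of carboxy does the same in both cores.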